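Aryl ether series: sulfone and nitrile head groups compared

The compounds below may be only part of what the source reports. "The series", "measured", "known", "first", "only" and "open" are said of these compounds alone.

Measured so far:
compound 1, `CC(C)(C)OC(=O)N1CCC(O[C@H]2CC[C@H](Oc3ccc(S(C)(=O)=O)cc3F)CC2)CC1`, 61 nM
compound 2, `CC(C)(C)OC(=O)N1CCC(O[C@H]2CC[C@H](Oc3ccc(C#N)cc3)CC2)CC1`, 45 nM

Both compounds share the same core and differ only in the aromatic group on the ether oxygen. In a functional assay on isolated protein for agonist activity at Glucose-dependent insulinotropic receptor (Rattus norvegicus), read by HTRF and cAMP accumulation (a higher number here means that more compound is needed for the effect, a lower number that less compound is needed), compound 1 gives 61 nM and compound 2 gives 45 nM. Compound 2 shows the lower of the two numbers, but the gap to compound 1 lies within the scatter, so no order between the two can be read from these values.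

The next compound, compound 3 (`CC(C)(C)OC(=O)N1CCC(O[C@H]2CC[C@H](Oc3cnc(S(C)(=O)=O)cn3)CC2)CC1`), changes the aromatic group of compound 2 again: 5-(methylsulfonyl)pyrazin-2-yl in place of 4-cyanophenyl on an oxygen on a saturated carbon. Going by the values given here, with only two measured compounds and no directly comparable step between them, there is no measured guide for the size of this change; the two values so far show that a methylsulfonyl-bearing ring and a nitrile-bearing ring both give numbers in the same range.

The expectation for compound 3 is a step of about a 1.8-fold higher number from compound 2 to compound 3 (0.25 log units; within the scatter) in this assay, that is, no change beyond the scatter, with a modest rise being the more likely direction if any. Compound 3 is estimated at 80 nM, with a range from 25 nM to 250 nM.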

Compound 3, half-maximal effective concentration: 64 nM
Estimate against measurement, compound 3: 1.3-fold (0.10 log units) above; the measured number falls inside the stated range.
By their numbers in this assay, from the lowest: compounds 2, 1 and 3 (each within the scatter of the next).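

In this assay, going by these compounds alone, the exchange of 4-cyanophenyl for 5-(methylsulfonyl)pyrazin-2-yl on an oxygen on a saturated carbon gives the first direct step at this place, a 1.4-fold higher number from compound 2 to compound 3 (0.15 log units; within the scatter). This single step spans a carbon-only aromatic ring with a nitrile and a ring with 2 hetero atoms carrying a methylsulfonyl group, with 10 heavy atoms in place of 8 and 4 hydrogen-bond acceptors in place of 1, and it still does not leave the scatter, so at this place and with the shared core held constant, this exchange is tolerated without a readable loss or gain. Nothing at hand on these compounds bears on why the number stays within the scatter across this exchange.

On these data alone, with no step beyond the scatter so far, it remains open how far the number can move at this place, and so which features of the aromatic group matter, if any. As far as these compounds go, whether a carboxylic acid or an amine on the aromatic ring in place of the nitrile or methylsulfonyl group would keep the number in this range also remains open.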